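The source may report more compounds than this note shows. Statements on the series, on what has been measured and on what is new or still open speak of the compounds shown alone.

Four compounds share a selenium-bearing core capped on both sides by amide groups. Compound 1 `C[Se]/C(=N\C(=O)c1cccs1)NC(=O)c1cccs1` carries a methyl on the selenium and thiophene-based amides; compound 3 `O=C(/N=C(/NC(=O)c1cccs1)[Se]Cc1ccccc1)c1cccs1` is its benzyl counterpart. Compound 2 `O=C(/N=C(/NC(=O)c1ccno1)[Se]Cc1ccccc1)c1ccno1` also carries the benzyl but has isoxazole-based amides, and compound 4 `C[Se]/C(=N\C(=O)c1ccno1)NC(=O)c1ccno1` is the methyl counterpart of compound 2. The difference between the two cores is not broken down here.

In a functional assay on PC-3 cells (Homo sapiens) for cytotoxicity, read by MTT assay, with a stated time of 72 h (on this read-out higher numbers stand for weaker inhibition of growth and lower numbers for stronger inhibition of growth), compound 1 gives 63000 nM. Compound 3 returns only a limit of the assay, > 100000 nM. Compound 2 likewise returns only a limit, > 100000 nM. The change from compound 3 to compound 1, (hydrogen in place of phenyl on a saturated chain carbon bound to a selenium atom), produced an at least 1.5-fold lower number from compound 3 to compound 1 (0.20 log units; that floor lies within the scatter), and that floor comes from the limit of > 100000 nM in this assay, at which 2 of the 3 values shown sit.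

The same kind of change, (hydrogen in place of phenyl on a saturated chain carbon bound to a selenium atom), leads from compound 2 to compound 4. The expected step is an at least 1.1-fold lower number from compound 2 to compound 4 (0.04 log units; that floor lies within the scatter), a small one. That expectation rests on the measured step of an at least 1.5-fold lower number from compound 3 to compound 1 (0.20 log units; that floor lies within the scatter) and on compound 2 standing at the limit of > 100000 nM in this assay, at which 2 of the 3 values shown sit. Compound 4 is therefore estimated at 90000 nM, between 35000 nM and 250000 nM, with a fair chance that it too returns only a limit.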

Compound 4, concentration for total growth inhibition: 39300 nM
Beside the measured number, compound 4's estimate is 2.3-fold (0.36 log units) above it; the range from low to high includes it.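

In this assay, replacing the benzyl on the selenium with methyl gives an at least 2.5-fold lower number from compound 2 to compound 4 (0.40 log units; beyond the scatter), so on the core of compound 2 this change has a clear effect. Set beside the earlier step, the change lowers the number on both cores, but only on this core does the smallest possible step clear the usual scatter: the same change on two cores in this assay, an at least 1.5-fold lower number (0.20 log units; that floor lies within the scatter) from compound 3 to compound 1 and an at least 2.5-fold lower number (0.40 log units; beyond the scatter) from compound 2 to compound 4; the limit leaves it open whether they differ. This shows that the change can be carried to a second core without reversing its direction, but it does not give the true size of either step or show that the two cores respond alike, and the reading is limited by how many benzyl compounds reach the assay's ceiling: the limit of > 100000 nM in this assay, at which 2 of the 4 values shown sit.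

The compounds shown hold only benzyl and methyl at this place, so it stays open how a longer chain, such as propyl, or a chain ending in an amine or a carboxylic acid would behave there. Also open, from the compounds shown here alone, is whether the effect of the change would hold in any other cell line.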